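Working notes: pyridin-2-yl carbonyl on the carbamate-bearing core

The compounds below may be only part of what the source reports. "The series", "measured", "known", "first", "only" and "open" are said of these compounds alone.

Measured so far:
Compound 1 `CCCn1c(NC(=O)c2ccccn2)nc2cc(C(N)=O)cc(OC)c21` gives > 100000 nM in an assay for activation of interferon regulatory factor 3 (Homo sapiens), read by a luciferase reporter, with a stated time of 20 h; a higher number here means that more compound is needed for the effect, a lower number that less compound is needed; this value is a limit of the assay, not a number.
Compound 2 `COc1cc(C(N)=O)cc2nc(NC(=O)c3ccc4ccccc4n3)n(CCCNC(=O)OCc3ccccc3)c12` gives > 100000 nM in this assay; this value is a limit.
Compound 3 `COc1cc(C(N)=O)cc2nc(NC(=O)c3nccc4ccccc34)n(CCCNC(=O)OCc3ccccc3)c12` gives > 100000 nM in this assay; this value is a limit.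

Compound 3 therefore stands at the limit in this assay, and the same holds for every value shown here, as the limit of > 100000 nM in this assay, at which 3 of the 3 values shown sit, records. Going by the values given here, the one comparison available among measured compounds, a step that the two limits leave unreadable from compound 2 to compound 3, is unreadable because both ends are limits, so no measured step gives a size for a change of the aryl group on the carbonyl carbon.

Compound 4 `COc1cc(C(N)=O)cc2nc(NC(=O)c3ccccn3)n(CCCNC(=O)OCc3ccccc3)c12` differs from compound 3 in one place: pyridin-2-yl in place of isoquinolin-1-yl on a carbonyl carbon. Compound 1 carries the same pyridin-2-yl on the carbonyl carbon, on a core with a propyl chain instead of the carbamate-bearing chain, and it too gives only a limit in this assay.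

With every value a limit and no readable step, the expected size of the step is a step that the limit leaves unreadable from compound 3 to compound 4, which is none beyond the scatter that can be supported. Compound 4 is therefore estimated at 150000 nM in this assay, within a range of 50000 nM to 500000 nM, most probably returned again as a limit.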

Compound 4, half-maximal effective concentration: > 100000 nM
Compound 4: only a limit was reported; the forecaster's own chance of this, stated with the estimate: 85%; the middle value does not contradict the limit.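

In this assay compound 4 gives > 100000 nM, a limit of the assay and not a number. The steps linking compound 4 to compound 1, compound 2 and compound 3 cannot be read, because all four compounds sit at one limit: the limit of > 100000 nM in this assay, at which 4 of the 4 values shown sit. The compounds shown leave open how large any change on the carbonyl carbon is in this assay, and whether any compound of the series gives a measurable value there.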